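The compounds below may be only part of what the source reports. "The series", "measured", "known", "first", "only" and "open" are said of these compounds alone.

Of the compounds shown here, three sharing one core have been measured in a functional assay on L5178Y cells (Mus musculus) for inhibition, read by MTT assay, with a stated time of 24 h (on this read-out higher numbers stand for weaker inhibition and lower numbers for stronger inhibition), and a fourth awaits its number. Compound 1 `COc1cc(O)c2c(c1)O[C@H](c1ccc(O)cc1)C/C2=N\NC(=O)Cc1c[nH]c2ccccc12` carries an (1H-indol-3-yl)methyl group on the carbonyl carbon. In this assay compound 1 reaches only a limit of the assay, >= 11300 nM. Compound 2 `COc1cc(O)c2c(c1)O[C@H](c1ccc(O)cc1)C/C2=N\NC(=O)OCc1ccccc1` differs from compound 1 by benzyloxy in place of (1H-indol-3-yl)methyl on a carbonyl carbon. In this assay compound 2 likewise gives a limit, >= 11300 nM. Because of the limit of >= 11300 nM in this assay, at which 2 of the 3 values shown sit, the step that the two limits leave unreadable from compound 1 to compound 2. Compound 3 `COc1ccc([C@@H]2C/C(=N\NC(=O)Cc3c[nH]c4ccccc34)c3c(O)cc(OC)cc3O2)cc1` differs from compound 1 by methyl in place of hydrogen on an oxygen on an aromatic ring. In this assay, among the measured compounds shown here, compound 3 gives 8600 nM, the only number among the three; the step of an at least 1.3-fold lower number from compound 1 to compound 3 (0.11 log units; that floor lies within the scatter).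

Compound 4 `COc1ccc([C@@H]2C/C(=N\NC(=O)OCc3ccccc3)c3c(O)cc(OC)cc3O2)cc1` has not been measured. For the measured compounds named here, it differs from compound 3 by benzyloxy in place of (1H-indol-3-yl)methyl on a carbonyl carbon, which is the same change as the one between compound 1 and compound 2, made here on the core of compound 3 rather than on that of compound 1; the two cores differ by methyl in place of hydrogen on an oxygen on an aromatic ring, and the place of the change is the same in both pairs. Going by the values given here, since the earlier step could not be read, the only anchor is compound 3 with 8600 nM, and the expected step of a 1.3-fold higher number from compound 3 to compound 4 (0.11 log units; within the scatter) is estimated to be small. Compound 4 is therefore expected to give about 11000 nM in this assay, with a likely range from 5500 nM to 25000 nM, and a fair chance that only a limit is reported.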

Compound 4, half-maximal inhibitory concentration: > 100000 nM
Compound 4: only a limit was reported; the forecaster's own chance of this, stated with the estimate: 50%; middle value at least 9.0-fold (0.95 log units) from the limit.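

In this assay, benzyloxy in place of (1H-indol-3-yl)methyl on a carbonyl carbon gives an at least 11-fold higher number from compound 3 to compound 4 (1.06 log units; beyond the scatter), so on the core of compound 3 this change does not pass unnoticed. The result for compound 4 is a limit of the assay and not a number: the limit of > 100000 nM in this assay, at which 1 of the 4 values shown sits. This shows the size of the change on one core only and does not show that the same step holds on the core of compound 1, for the step from compound 1 to compound 2 and the step from compound 2 to compound 4 cannot be read, because each of these pairs rests on limits: the limit of >= 11300 nM in this assay, at which 2 of the 4 values shown sit.

Among the compounds shown here, compound 3 gives 8600 nM, the only number among the four, so how far the series reaches in this assay is anchored at a single point, and whether the step on the core of compound 3 reflects the loss of (1H-indol-3-yl)methyl or the arrival of benzyloxy stays open. Also open, from the compounds shown here alone, is what another group on the same carbonyl carbon would give on either core, for instance a chain ending in an amine, a chain ending in a carboxylic acid, or a longer carbon chain.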